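This account rests on a few compounds, and the source may have more. Where it says the series, first, only, none or still open, it means among the compounds named here.

Measured so far in a functional assay on MDA-MB-231 cells (Homo sapiens) for cytotoxicity, read by MTT assay, with a stated time of 48 h (a lower number here means a stronger inhibitor, a higher number a weaker inhibitor), each entry a limit of the assay and not a number:
- compound 1 `CNC(=O)CC[C@H](NS(=O)(=O)c1ccc([N+](=O)[O-])cc1)C(=O)O`: > 500000 nM
- compound 2 `CC(C)NC(=O)CC[C@H](NS(=O)(=O)c1ccc([N+](=O)[O-])cc1)C(=O)O`: > 500000 nM
- compound 3 `CC(C)CNC(=O)CC[C@H](NS(=O)(=O)c1ccc([N+](=O)[O-])cc1)C(=O)O`: > 500000 nM

Compound 3 has no number of its own, only the limit > 500000 nM. For the measured compounds named here, the series so far comes to the limit of > 500000 nM in this assay, at which 3 of the 3 values shown sit.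

The next compound, compound 4 `CCCCCNC(=O)CC[C@H](NS(=O)(=O)c1ccc([N+](=O)[O-])cc1)C(=O)O`, carries butyl in place of isopropyl on a saturated chain carbon bound to an amide-type nitrogen, which also reads as isobutyl to pentyl. Counted difference: butyl in place of isopropyl on a saturated chain carbon bound to an amide-type nitrogen.

The measured steps that bear on this change are a step that the two limits leave unreadable from compound 1 to compound 2, a step that the two limits leave unreadable from compound 1 to compound 3 and a step that the two limits leave unreadable from compound 2 to compound 3. All three alter the same amide substituent, and none gives a size to carry over. On that basis, the expected a number no higher from compound 3 to compound 4 (the limit leaves the size open) is no larger than the scatter, with no direction favoured, and another limit in this assay is the likeliest reading. Compound 4 is estimated at 500000 nM, with an expected range from 250000 nM to 1000000 nM.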

Compound 4, half-maximal inhibitory concentration: 162000 nM
Beside the measured number, compound 4's estimate is 3.1-fold (0.49 log units) above it, outside the stated range (below it).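

In this assay, compound 4 is the first member of the series to give a number rather than a limit: the limit of > 500000 nM in this assay, at which 3 of the 4 values shown sit.

Pentyl on the amide-type nitrogen gives an at least 3.0-fold lower number from compound 3 to compound 4 (0.48 log units; beyond the scatter), an at least 3.0-fold lower number from compound 2 to compound 4 (0.48 log units; beyond the scatter) and an at least 3.0-fold lower number from compound 1 to compound 4 (0.48 log units; beyond the scatter), so each of these steps is a lower bound on the true change. The steps among compound 1, compound 2 and compound 3 cannot be read, so this substituent is shown to move the read-out only through compound 4, with methyl, isopropyl and isobutyl all remaining at the limit.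

The compounds shown leave open whether a longer chain such as hexyl or octyl continues this shift, or whether a benzyl group on the amide-type nitrogen gives a number at all. As far as these compounds go, the true size of each step also remains open.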